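Hydroxamic acid cyclopropane in place of a carboxymethoxy group

This account rests on a few compounds, and the source may have more. Where it says the series, first, only, none or still open, it means among the compounds named here.

Of the compounds shown here, two have been measured in a functional assay on CHO cells for agonist activity at Free fatty acid receptor 1 (Homo sapiens); on this read-out higher numbers stand for an effect only at larger amounts of compound and lower numbers for an effect already at smaller amounts. Compound 1 `Cc1nc(-c2ccc(C(F)(F)F)cc2)sc1CNc1ccc(CCC(=O)O)cc1` gives 67.6 nM in this assay, while compound 2 `O=C(O)COc1ccc(NCc2cccc(Oc3ccccc3)c2)cc1` gives 2040 nM, the higher of the two numbers, separated from compound 1 by a gap beyond the usual scatter. Among the compounds with values here, no step between compounds differing in a single place has been recorded, so nothing measured tells how a change at the acid end shifts the read-out.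

Compound 3 `O=C(NO)[C@H]1C[C@@H]1c1ccc(NCc2cccc(Oc3ccccc3)c2)cc1` is the next compound and differs from compound 2 in one place: 2-(hydroxycarbamoyl)cyclopropyl in place of carboxymethoxy on an aromatic carbon. Compound 3 is expected to remain near the weaker end of this small set, with a modest rise in the read-out that may not exceed the scatter, giving an estimated step of a 1.7-fold higher number from compound 2 to compound 3 (0.23 log units; within the scatter). The estimate for compound 3 in this assay is 3500 nM, with a range from 900 nM to 14000 nM.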

Compound 3, half-maximal effective concentration: 14.8 nM
For compound 3 the middle estimate is 240-fold (2.37 log units) above the measured one; the whole stated range lies above it.
By their numbers in this assay, from the lowest: compound 3; then compound 1; then compound 2.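

With the rest of compound 2 unchanged, putting 2-(hydroxycarbamoyl)cyclopropyl in place of carboxymethoxy gives a 140-fold lower number from compound 2 to compound 3 (2.14 log units; beyond the scatter) in this assay and so shows that the read-out is highly sensitive to the group at this position. Compounds 1 and 2 both end in a carboxylic acid, whereas compound 3 shows that a compound without one at this position can still give a low number. Nothing available here accounts for the size of this step.

From the compounds shown here alone, the swap changes the cyclopropane ring and the hydroxycarbamoyl group together, so their separate contributions remain unknown; a cyclopropane bearing a carboxylic acid, or a hydroxycarbamoyl group on an ethyl chain, would separate them. Going by these compounds, the contribution of the 2 defined stereocentres is also open, and the opposite arrangement of the cyclopropane substituents would test it.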